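The source may report more compounds than this note shows. Statements on the series, on what has been measured and on what is new or still open speak of the compounds shown alone.

Compound 3 `N#Cc1ccc(NC(=S)N/N=C/c2ccc3ccccc3n2)cc1` has the highest of the two numbers on record in a functional assay on HT-29 cells (Homo sapiens) for antiproliferative activity, read by sulforhodamine B assay, with a stated time of 72 h (a higher number here means a weaker inhibitor, a lower number a stronger inhibitor), giving 15600 nM. Its nearest neighbour is compound 1 `CN(C)C(=S)N/N=C/c1ccc2cccnc2n1`, which in this assay gives 410 nM. Compound 2 `Fc1ccccc1NC(=S)N/N=C/c1ccc2ccccc2n1` reaches only the limit of this assay and is recorded as > 100000 nM, a limit and not a number (the limit of > 100000 nM in this assay, at which 1 of the 3 values shown sits). Going by the values given here, the one measured step on an amide-type nitrogen, an at least 6.4-fold lower number from compound 2 to compound 3 (0.80 log units; beyond the scatter), went toward lower numbers. Compound 4 `NC(=S)N/N=C/c1ccc2ccccc2n1` differs from compound 3 in this way: hydrogen in place of 4-cyanophenyl on an amide-type nitrogen. Among the compounds with values here, no measured step removes a whole aryl group, so the direction is open; the expected change is a 1.6-fold lower number from compound 3 to compound 4 (0.19 log units; within the scatter). The estimate for compound 4 in this assay is 10000 nM, ranging from 2000 nM to 60000 nM.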

Compound 4, half-maximal inhibitory concentration: 100000 nM
Compound 4: middle estimate off by 10-fold (1.00 log units), on the low side; measured number outside the range, above it.
By their numbers in this assay, from the lowest: compound 1; then compound 3; then compound 4.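

In this assay, this amide-type nitrogen does not tolerate the loss of its aryl group without change: the result is a 6.4-fold higher number from compound 3 to compound 4 (0.81 log units; beyond the scatter). Going by these compounds alone, the earlier step compared only two aryl groups, whereas this one shows that 4-cyanophenyl gives a lower number than hydrogen in this place. Hydrogen in place of 2-fluorophenyl on this nitrogen gives a number no higher from compound 2 to compound 4 (the limit leaves the size open). Compound 2 stands at a limit and not a number, so the size of this step cannot be read: the limit of > 100000 nM in this assay, at which 1 of the 4 values shown sits.

From the compounds shown here alone, it remains open whether an unsubstituted phenyl would keep the number of compound 3. The same applies to a non-aromatic group on this nitrogen, such as ethyl or cyclohexyl.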